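A few compounds are considered here, and "the series" means these few. Any claim that something is new, unique, unknown or untested is made for them only; others in the source may bear on it.

Notes on the series. Among the measured compounds shown here, compound 1 `Cc1nc(-c2ccccc2)c(C(=O)N2CCN(c3cccc(C(F)(F)F)c3)CC2)o1` carries the only number reported: in a functional assay on HL-60 cells (Homo sapiens) for inhibition, read by MTT assay, with a stated time of 72 h (on this read-out higher numbers stand for weaker inhibition and lower numbers for stronger inhibition), compound 1 gives 153 nM. Compound 2 `COc1cccc(N2CCN(C(=O)c3oc(C(F)(F)F)nc3-c3ccc(F)cc3)CC2)c1` is recorded in this assay as "not active" (no number reported), without a number, and it differs from compound 1 in more than one place. Compound 3 `COc1cccc(N2CCN(C(=O)c3oc(C)nc3-c3ccccc3)CC2)c1` is not yet measured; it differs from compound 1 by methoxy in place of trifluoromethyl on an aromatic carbon. For the measured compounds named here, no step between measured compounds is available, so the expected step of a 2.6-fold higher number from compound 1 to compound 3 (0.42 log units; beyond the scatter) from compound 1 toward weaker inhibition is an estimate only, modestly beyond the scatter. Compound 3 is expected to give 400 nM in this assay, with a range from 120 nM to 2000 nM.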

Compound 3, half-maximal inhibitory concentration: 34.8 nM
For compound 3 the middle estimate is 11-fold (1.06 log units) above the measured one; the whole stated range lies above it.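

Changing 3-(trifluoromethyl)phenyl to 3-methoxyphenyl in this assay gives a 4.4-fold lower number from compound 1 to compound 3 (0.64 log units; beyond the scatter) and thus moves toward stronger inhibition. This position on the aromatic ring therefore responds to the group it carries, and trifluoromethyl is not needed there for activity in compound 3. Nothing measured here offers an explanation for this step.

One pair cannot separate the effect of the oxygen from that of the group's size. A hydroxyl, an ethoxy or an amine at this position would help to define the trend.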